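Changing the Ester Group of a Core

This account rests on a few compounds, and the source may have more. Where it says the series, first, only, none or still open, it means among the compounds named here.

Measured compounds:
compound 1 `CC1=C(C(=O)OC(C)(C)C)C(c2ccoc2)NC(=O)N1` gives 11%
compound 2 `CC1=C(C(=O)OC(C)(C)C)C(c2cccs2)NC(=O)N1` gives 26%
compound 3 `CC1=C(C(=O)OC(C)(C)C)C(c2ccsc2)NC(=O)N1` gives 15%

These three were tested in an assay on membranes from CHO cells for displacement of a labelled ligand from adenosine receptor A1 (Homo sapiens), read by scintillation counting, with a stated time of 60 min, tested at 1 uM; a higher number here means more inhibition at the concentration tested (going by the name of the read-out), a lower number less inhibition. Compound 1 stands lowest of the three numbers; compound 3 is nearest, a step within the usual scatter (a number 4 percentage points higher from compound 1 to compound 3 (within the scatter)), while compound 2 lies furthest, beyond it (a number 15 percentage points higher from compound 1 to compound 2 (beyond the scatter)). Compound 4 `CC1=C(C(=O)OCC2CC2)C(c2ccoc2)NC(=O)N1` differs from compound 1 by cyclopropylmethyl in place of tert-butyl on an oxygen next to a carbonyl group. For the measured compounds named here, none of the measured steps touches this part of the molecule: all three alter the aromatic ring on a saturated ring carbon, so they give no direct guide. Without bearing steps, the expectation for compound 4 is a change of a number 1 percentage points higher from compound 1 to compound 4 (within the scatter) in this assay, none beyond the scatter, estimated at 12% with a range from 0% to 28%.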

Compound 4, a percentage reported as inhibition, at one concentration (the size of the read-out at that concentration, not a potency): 29%
For compound 4 the middle estimate is 17 percentage points below the measured one; the whole stated range lies below it.
By their numbers in this assay, from the lowest: compounds 1 and 3 (each within the scatter of the next); then compounds 2 and 4 (each within the scatter of the next).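

The ester group can shift the number in this assay: with the furan-3-yl ring held fixed, cyclopropylmethyl in place of tert-butyl on the oxygen gives a number 18 percentage points higher from compound 1 to compound 4 (beyond the scatter). So this position, and not only the aromatic ring, can move the result, although both groups count the same heavy atoms and differ in the three-membered ring that enters. Nothing available explains this rise.

From the compounds shown here alone, whether a longer chain such as n-butyl or a small methyl group would do the same stays open, as does whether this swap behaves alike with thiophen-2-yl in place of furan-3-yl.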